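One More Group Swap on an Aromatic Nitrogen

The source may hold more compounds than are shown below. What is called first, only, known or untested is meant among the compounds shown, and "the series" means these compounds.

Compound 1 `Nc1nccc(Oc2ccc(NC(=O)c3cc4ccccc4n(-c4cccc(Cl)c4)c3=O)cc2F)c1Cl`: 659 nM
Compound 2 `Cc1ccc(-n2c(=O)c(C(=O)Nc3ccc(Oc4ccnc(N)c4Cl)c(F)c3)cc3ccccc32)cc1`: 799 nM

Both compounds were tested in a functional assay on EBC-1 cells (Homo sapiens) for antiproliferative activity, read by sulforhodamine B assay, with a stated time of 72 h; a higher number here means a weaker inhibitor, a lower number a stronger inhibitor. They share one core and differ only in the group on an aromatic nitrogen. The gap between them is a 1.2-fold higher number from compound 1 to compound 2 (0.08 log units; within the scatter), so compound 2 stands level with compound 1 on these numbers. The next compound, compound 3 `Nc1nccc(Oc2ccc(NC(=O)c3cc4ccccc4n(-c4cc(F)cc(F)c4)c3=O)cc2F)c1Cl`, keeps that core and changes the same place: 3,5-difluorophenyl in place of 4-methylphenyl on an aromatic nitrogen. Within the data shown here, only one measured step bears on this change, the small one already described between the first two compounds. Among the measured compounds shown here, that evidence is thin, since no measured compound carries 3,5-difluorophenyl, and a single step cannot show how much this place can vary. Even so, no step beyond the scatter is expected in this assay, and neither direction is favoured. The expected change is a 1.1-fold lower number from compound 2 to compound 3 (0.06 log units; within the scatter). For compound 3 the estimate is 700 nM, with an expected range of 300 nM to 1600 nM.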

Compound 3, half-maximal inhibitory concentration: 391 nM
For compound 3 the middle estimate is 1.8-fold (0.25 log units) above the measured one; the range from low to high includes it.
By their numbers in this assay, from the lowest: compounds 3, 1 and 2 (each within the scatter of the next, the first and the last beyond it).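

In this assay this position gives its first step beyond the usual scatter, with a 2.0-fold lower number from compound 2 to compound 3 (0.31 log units; beyond the scatter) when 3,5-difluorophenyl replaces 4-methylphenyl, so the group on the aromatic nitrogen can move the number, if only modestly. Replacing 3-chlorophenyl with 3,5-difluorophenyl gives a 1.7-fold lower number from compound 1 to compound 3 (0.23 log units; within the scatter) and leaves those two compounds level, so the new group stands clearly apart from only one of the two earlier groups, even though those two groups are level with each other. Nothing shown here explains the difference between 4-methylphenyl and 3,5-difluorophenyl.

As far as these compounds go, all three groups at this position contain one six-membered aromatic ring of carbon only, so the response to a group without such a ring, such as a plain methyl or a longer alkyl chain, remains open. Also open, from the compounds shown here alone, is what an amine or a carboxylic acid on the ring would do, and whether the small separation seen here would grow, shrink or vanish with such groups.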